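The source may report more compounds than this note shows. Statements on the series, on what has been measured and on what is new or still open speak of the compounds shown alone.

Measured compounds:

Compound 1 `c1cc2[nH]cc(CCCN3CCCCC3)c2cc1-n1cnnc1` gives 15 nM in an assay on CHO cells for binding affinity to 5-hydroxytryptamine receptor 1B (Homo sapiens); on this read-out lower numbers stand for stronger inhibition and higher numbers for weaker inhibition.
Compound 2 `CN(Cc1ccccc1)CC1CCN(CCCc2c[nH]c3ccc(-n4cnnc4)cc23)CC1` gives 28 nM in this assay.
Compound 3 `CN(Cc1ccccc1)C1CCN(CCCc2c[nH]c3ccc(-n4cnnc4)cc23)CC1` gives 145 nM in this assay.

Compound 3 stands at the highest number of the three. Its nearest neighbour is compound 2: the step of a 5.2-fold higher number from compound 2 to compound 3 (0.71 log units; beyond the scatter) lies beyond the scatter. Its furthest is compound 1: the step of a 9.7-fold higher number from compound 1 to compound 3 (0.99 log units; beyond the scatter) lies beyond the scatter as well. By contrast, the step of a 1.9-fold higher number from compound 1 to compound 2 (0.27 log units; within the scatter) stays within the scatter.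

Compound 4 `c1ccc(CNC2CCN(CCCc3c[nH]c4ccc(-n5cnnc5)cc34)CC2)cc1` is compound 3 with one change: hydrogen in place of methyl on an amine nitrogen. Among the compounds with values here, no measured step touches this amine nitrogen directly. The two steps that involve compound 3 describe attaching the benzyl(methyl)amino group to the saturated ring carbon, or moving it closer by one carbon; both shifted this assay by a modest amount, but neither removes a methyl from the amine nitrogen. On the evidence at hand, the step of a 1.2-fold lower number from compound 3 to compound 4 (0.08 log units; within the scatter) is expected to stay within the scatter, with a wide spread to either side because the shown steps cannot anchor it.

Compound 4 is therefore estimated to give 120 nM in this assay, within a range from 40 nM to 400 nM.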

Compound 4, half-maximal inhibitory concentration: 125 nM
The estimate for compound 4 lay 1.0-fold (0.02 log units) below the measured number, and the stated range covers the measured number.
By their numbers in this assay, from the lowest: compounds 1 and 2 (each within the scatter of the next); then compounds 4 and 3 (each within the scatter of the next).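

In this assay the amine nitrogen whose other neighbours are a saturated chain carbon and a saturated ring carbon is now probed directly, and hydrogen in place of methyl gives a 1.2-fold lower number from compound 3 to compound 4 (0.06 log units; within the scatter) as its result, so methyl and hydrogen cannot be told apart at this nitrogen. The distance from the other two compounds survives the loss of the methyl, with a 4.5-fold higher number from compound 2 to compound 4 (0.65 log units; beyond the scatter) and an 8.3-fold higher number from compound 1 to compound 4 (0.92 log units; beyond the scatter) both showing that benzylamino on the saturated ring carbon stays apart from the (benzyl(methyl)amino)methyl group and from plain hydrogen at that carbon, much as benzyl(methyl)amino did. Nothing available from other measurements bears on why the methyl makes so little difference here.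

The compounds shown leave open whether this tolerance extends to larger groups on the same nitrogen, such as an ethyl or an acetyl group, or holds only for the small swap of methyl and hydrogen. They also leave open whether hydrogen in place of methyl would be equally silent in the (benzyl(methyl)amino)methyl group of compound 2, where a longer chain separates the amine from the saturated ring carbon.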